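The source may hold more compounds than are shown below. What is called first, only, known or untested is meant among the compounds shown, and "the series" means these compounds.

Measured so far in a functional assay on NCI-H460 cells (Homo sapiens) for cytotoxicity, read by MTT assay, with a stated time of 72 h; on this read-out lower numbers stand for stronger inhibition and higher numbers for weaker inhibition: compound 1 `O=C(Nc1ccc(-n2ncc3c(Br)cccc32)cc1)Nc1ccc(Cl)c(C(F)(F)F)c1` gives 1300 nM; compound 2 `CNc1cccc2c1cnn2-c1ccc(NC(=O)Nc2ccc(Cl)c(C(F)(F)F)c2)cc1` gives 2600 nM.

Compound 2 stands on the upper side of these two numbers, but its distance from compound 1 is small: the step of a 2.0-fold higher number from compound 1 to compound 2 (0.30 log units; within the scatter) sits within the scatter, so the two compounds cannot be told apart on this read-out. Compound 3 `COc1cccc2c1cnn2-c1ccc(NC(=O)Nc2ccc(Cl)c(C(F)(F)F)c2)cc1` differs from compound 2 by methoxy in place of methylamino on an aromatic carbon. Within the data shown here, the only measured step that touches the same position on the shared core is the one already given, a 2.0-fold higher number from compound 1 to compound 2 (0.30 log units; within the scatter), and it did not move the number beyond the scatter; no measured pair compares a methoxy with a methylamino directly. On that basis no change beyond the scatter is expected for compound 3, and the expected step is a 1.2-fold lower number from compound 2 to compound 3 (0.07 log units; within the scatter). Compound 3 is therefore estimated at 2200 nM, within a range from 800 nM to 6000 nM.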

Compound 3, half-maximal inhibitory concentration: 2200 nM
For compound 3 middle estimate and measured number coincide at the digits printed, within the range that was stated.
By their numbers in this assay, from the lowest: compounds 1, 3 and 2 (each within the scatter of the next).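

In this assay methoxy and methylamino now meet directly on this aromatic carbon (a 1.2-fold lower number from compound 2 to compound 3 (0.07 log units; within the scatter)), and the exchange, which takes the count of hydrogen-bond donors in the group from 1 to 0, stays within the scatter. The comparison with bromo on the same carbon (a 1.7-fold higher number from compound 1 to compound 3 (0.23 log units; within the scatter)) also stays within the scatter, so bromo, methylamino and methoxy cannot be told apart here on this read-out, in compounds that are otherwise the same. The data shown give no evidence on why these groups cannot be told apart.

On these data alone, whether any group on this aromatic carbon can move the number beyond the scatter remains open. A carboxylic acid, a primary amine or a longer alkoxy chain there would test that question, and the three compounds shown do not answer it.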